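Benzyl in Place of Methyl on the Pyrazole Nitrogen

The source may hold more compounds than are shown below. What is called first, only, known or untested is meant among the compounds shown, and "the series" means these compounds.

Measured compounds:
compound 1 `C[C@@H](O[C@H]1CN2C(=O)C=C(c3ccccc3)CC2[C@@H]1c1ccc(F)cc1)c1cc(C(F)(F)F)cc(C(F)(F)F)c1`: 89.5 nM
compound 2 `C[C@@H](O[C@H]1CN2C(=O)C=C(c3cc[nH]c(=O)c3)CC2[C@@H]1c1ccc(F)cc1)c1cc(C(F)(F)F)cc(C(F)(F)F)c1`: 3.9 nM
compound 3 `C[C@@H](O[C@H]1CN2C(=O)C=C(c3cnn(C)c3)CC2[C@@H]1c1ccc(F)cc1)c1cc(C(F)(F)F)cc(C(F)(F)F)c1`: 5.4 nM

In an assay on CHO cells for displacement of a labelled ligand from Substance-P receptor (Homo sapiens), in the presence of a further agent that is not named here (a higher number here means a weaker inhibitor, a lower number a stronger inhibitor), compound 3 gives 5.4 nM, the second highest of the three numbers. Its nearest neighbour is described by a 1.4-fold higher number from compound 2 to compound 3 (0.14 log units; within the scatter), its furthest by a 17-fold lower number from compound 1 to compound 3 (1.22 log units; beyond the scatter). Compound 4 `C[C@@H](O[C@H]1CN2C(=O)C=C(c3cnn(Cc4ccccc4)c3)CC2[C@@H]1c1ccc(F)cc1)c1cc(C(F)(F)F)cc(C(F)(F)F)c1` differs from compound 3 in one place: phenyl in place of hydrogen on a saturated chain carbon bound to an aromatic nitrogen. Among the measured compounds shown here, every measured step, including a 23-fold lower number from compound 1 to compound 2 (1.36 log units; beyond the scatter), exchanges the whole ring on the double-bonded ring carbon; none alters what sits on the aromatic nitrogen of that ring, so no measured step bears directly on this change. For compound 4 a small step is therefore expected, a 1.5-fold higher number from compound 3 to compound 4 (0.17 log units; within the scatter), with wide uncertainty. Compound 4 is estimated at 8 nM, within a range from 2 nM to 40 nM.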

Compound 4, half-maximal inhibitory concentration: 66 nM
Beside the measured number, compound 4's estimate is 8.3-fold (0.92 log units) below it; the whole stated range lies below it.
By their numbers in this assay, from the lowest: compounds 2 and 3 (each within the scatter of the next); then compounds 4 and 1 (each within the scatter of the next).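

Among the compounds shown here, the change of methyl to benzyl on the pyrazole gives a 12-fold higher number from compound 3 to compound 4 (1.09 log units; beyond the scatter) in this assay, so what sits on this aromatic nitrogen matters, which no earlier step could show. For the compounds shown here, with benzyl, the gain over phenyl disappears, as a 1.4-fold lower number from compound 1 to compound 4 (0.13 log units; within the scatter) shows, and a 17-fold higher number from compound 2 to compound 4 (1.23 log units; beyond the scatter) leaves this ring well short of the one in compound 2. No evidence here accounts for the drop.

Going by these compounds, it remains open whether ethyl on that nitrogen would behave like methyl or like benzyl. A longer chain ending in an amine or a carboxylic acid is also untested ground in these compounds.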